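The compounds below may be only part of what the source reports. "The series", "measured", "known", "first", "only" and "open" are said of these compounds alone.

Measured so far in an ADME assay on Vero cells (Chlorocebus sabaeus) for inhibition; a lower number here means that less compound is tolerated, a higher number that more compound is tolerated:
- compound 1 `O=C1/C(=C/c2ccccc2Cl)CCC/C1=C\c1ccccc1Cl`: 30600 nM
- compound 2 `COc1ccc(/C=C2\CCC/C(=C\c3ccccc3Cl)C2=O)cc1`: 238000 nM

Of these two, compound 2 has the higher number, so more of it is tolerated. The next structure, compound 3 `COc1ccc(/C=C2\CCC/C(=C\c3ccc(F)cc3)C2=O)cc1`, keeps the 4-methoxyphenyl of compound 2 and has 4-fluorophenyl in place of 2-chlorophenyl on a double-bonded chain carbon bound to a double-bonded ring carbon. For the measured compounds named here, only one measured step bears on this: a 7.8-fold higher number from compound 1 to compound 2 (0.89 log units; beyond the scatter). That step also removed a 2-chlorophenyl from the same kind of place, but 4-methoxyphenyl entered, not 4-fluorophenyl. Going by the values given here, no compound with 4-fluorophenyl has been measured, so this is thin evidence. A smaller step in the same direction is expected in this assay. The expected step is a 1.5-fold higher number from compound 2 to compound 3 (0.17 log units; within the scatter). For compound 3 the estimated value is 350000 nM, with an expected range of 100000 nM to 1000000 nM.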

Compound 3, half-maximal cytotoxic concentration: 378000 nM
The estimate for compound 3 lay 1.1-fold (0.03 log units) below the measured number; low and high end bracket the measured number.
By their numbers in this assay, from the lowest: compound 1; then compounds 2 and 3 (each within the scatter of the next).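

In this assay, a 1.6-fold higher number from compound 2 to compound 3 (0.20 log units; within the scatter), so with 4-methoxyphenyl held in place, compound 2 and compound 3 cannot be told apart. The earlier step, a 7.8-fold higher number from compound 1 to compound 2 (0.89 log units; beyond the scatter), showed that this kind of position can respond to a swap, whereas this one shows that 2-chlorophenyl and 4-fluorophenyl can stand in this place with no difference beyond the scatter. Nothing available explains either result.

Going by these compounds, whether 4-fluorophenyl would give a similar number with 2-chlorophenyl as the partner group, rather than 4-methoxyphenyl, remains open. So does the effect of a group of a different kind at this place, such as a phenyl ring carrying an amine or a carboxylic acid.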